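Working notes: from compound 2 to compound 3

The source may hold more compounds than are shown below. What is called first, only, known or untested is meant among the compounds shown, and "the series" means these compounds.

Measured so far in a functional assay on MCF7 cells (Homo sapiens) for cytotoxicity, read by MTT assay, with a stated time of 72 h; a higher number here means a weaker inhibitor, a lower number a stronger inhibitor
- compound 1 `CNC(=O)c1cc(Oc2ccc(C(=O)/C=C/c3ccco3)cc2)ccn1` gives "not determined" (no result reported)
- compound 2 `CNC(=O)c1cc(Oc2ccc(C(=O)/C=C/c3ccc(Cl)c(Cl)c3)cc2)ccn1` gives 13200 nM

Among the compounds with values here, compound 2 holds the only number, so it cannot yet be ranked against another compound. Compound 3 `CNC(=O)c1cc(Oc2ccc(C(=O)/C=C/c3ccccc3)cc2)ccn1` follows with phenyl in place of 3,4-dichlorophenyl on a double-bonded chain carbon bound to a double-bonded chain carbon and no other change. Within the data shown here, no measured step shows the effect of this change. In this assay a step no larger than the scatter is expected, if anything toward weaker inhibition, and this rests only on compound 2 at 13200 nM as the anchor. The estimate means a 1.5-fold higher number from compound 2 to compound 3 (0.18 log units; within the scatter) as the expected step. The expected value for compound 3 is 20000 nM within an estimated range of 8000 nM to 50000 nM as a working figure.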

Compound 3, half-maximal inhibitory concentration: 5960 nM
Compound 3: the middle estimate sits 3.4-fold (0.53 log units) above what was measured; the measured number lies below the stated range.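

Phenyl in place of 3,4-dichlorophenyl on a double-bonded chain carbon bound to a double-bonded chain carbon gives a 2.2-fold lower number from compound 2 to compound 3 (0.35 log units; beyond the scatter) in this assay. Within the data shown here, this is the first readable step: the position responds to this change, and the two chlorine atoms are not required for activity in this assay. Nothing available explains the step.

Going by these compounds, whether a single chlorine atom would give a number nearer compound 2 or compound 3 remains open. On these data alone, the effect of a methoxy group or an amine on the phenyl also remains open.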